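The compounds below may be only part of what the source reports. "The series", "measured", "known", "first", "only" and "open" are said of these compounds alone.

In a functional assay on K562 cells (Homo sapiens) for inhibition, read by sulforhodamine B assay, with a stated time of 48 h (on this read-out higher numbers stand for weaker inhibition of growth and lower numbers for stronger inhibition of growth), compound 1 `CCOC(=O)c1nn(-c2ccccc2)c(-c2ccc(F)cc2)c1CNC(C)(C)C`, which carries 4-fluorophenyl, gives 75700 nM; 161000 nM (2 entries). Compound 2 `CCOC(=O)c1nn(-c2ccccc2)c(-c2ccc(Cl)cc2)c1CNC(C)(C)C`, which carries 4-chlorophenyl, gives 57600 nM; > 559000 nM (2 entries). Compound 3 `CC(C)(C)NCc1c(C(=O)O)nn(-c2ccccc2)c1-c1ccc(F)cc1` gives only > 680000 nM, which is a limit and not a number. Its further entries hold no single number either. Compound 4 `CC(C)(C)NCc1c(C(=O)O)nn(-c2ccccc2)c1-c1ccc(Cl)cc1` has chloro in place of fluoro on an aromatic carbon, para to a large group: chloro in place of fluoro on an aromatic carbon. Going by the values given here, no measured pair shows this change alone. In this assay, a step no larger than the usual scatter is expected, in neither direction, and another limit would be no surprise. Compound 4 is expected at about 620000 nM, with an estimated range of 300000 nM to 1000000 nM.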

Compound 4, concentration for 50% growth inhibition: 364000 nM
Estimate against measurement, compound 4: 1.7-fold (0.23 log units) above, within the range that was stated.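

In this assay, chloro in place of fluoro on the aromatic carbon para to a large group gives an at least 1.8-fold lower number from compound 3 to compound 4 (0.27 log units; that floor lies within the scatter). Going by these compounds alone, this is the first pair to show this change alone, and compound 4 gives a single number, 364000 nM. The step is only a floor and its true size stays unknown, because compound 3 holds a limit and not a number: the limit of > 680000 nM in this assay, at which 1 of the 4 values shown sits.

The compounds shown leave open what bromo, methyl or methoxy on this same carbon would give. They also leave open whether a smaller amine in place of the tert-butylamine would shift these values.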